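Removing the Bromo Group from Compound 1

A few compounds are considered here, and "the series" means these few. Any claim that something is new, unique, unknown or untested is made for them only; others in the source may bear on it.

Compound 1, `COc1ccc(S(=O)(=O)N2CCc3cc(Br)cc(NC(=O)c4ccco4)c32)cc1`: 78 nM
Compound 2, `COc1ccc(S(=O)(=O)N2CCc3cccc(NC(=O)c4ccncc4)c32)cc1`: 8.8 nM
Compound 3, `COc1ccc(S(=O)(=O)N2CCc3cccc(NS(=O)(=O)c4ccc([N+](=O)[O-])cc4)c32)cc1`: 933 nM

Of the compounds shown here, three sharing the core of compound 1 have been measured in a functional assay on MKN-45 cells (Homo sapiens) for cytotoxicity; a lower number here means a stronger inhibitor, a higher number a weaker inhibitor. Compound 1 gives 78 nM, the second highest of the three numbers. Its nearest neighbour is compound 2, whose value of 8.8 nM is lower by a margin beyond the scatter. Compound 3 stands furthest from it with 933 nM, higher by a margin also beyond the scatter, so the three values are clearly separated.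

Compound 4, `COc1ccc(S(=O)(=O)N2CCc3cccc(NC(=O)c4ccco4)c32)cc1`, has not yet been measured in this assay. It differs from compound 1 in one place: hydrogen in place of bromo on an aromatic carbon. Among the measured compounds shown here, nothing among the measured compounds shows a step of exactly this kind, so the size of the effect is uncertain. With compound 2 at 8.8 nM showing that the core without bromo can reach a low number, compound 4 is expected to sit close to compound 1, perhaps slightly lower, with a step from a 1.6-fold lower number from compound 1 to compound 4 (0.19 log units; within the scatter) that is expected to be small. The estimate for compound 4 in this assay is 50 nM, expected within 12 nM to 200 nM.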

Compound 4, half-maximal inhibitory concentration: 10.7 nM
For compound 4 the middle estimate is 4.7-fold (0.67 log units) above the measured one; measured number below the stated range.
By their numbers in this assay, from the lowest: compounds 2 and 4 (each within the scatter of the next); then compound 1; then compound 3.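

In this assay, among the compounds shown here, the change from bromo to hydrogen gives the first direct reading at this aromatic carbon, meta to the ((furan-2-yl)carbonyl)amino group: a 7.3-fold lower number from compound 1 to compound 4 (0.86 log units; beyond the scatter), so with everything else held the same, the compound carrying bromo gives the higher number. The second comparison, with furan-2-yl in place of pyridin-4-yl on a carbonyl carbon, gives a 1.2-fold higher number from compound 2 to compound 4 (0.08 log units; within the scatter), so these two groups cannot be told apart in this assay when the aromatic carbon carries hydrogen. Of the two single changes now read, only the loss of bromo moves the number beyond the scatter, although a single pair cannot show how general that effect is.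

On these data alone, it remains open whether a chloro, methyl, methoxy or amino group on this aromatic carbon would give a number closer to that of hydrogen or of bromo, and whether bromo would produce a step of similar size with pyridin-4-yl on the carbonyl carbon. Nothing measured here explains why the number changes when bromo is removed.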